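Amide substituent changes in the shared core series

The source may hold more compounds than are shown below. What is called first, only, known or untested is meant among the compounds shown, and "the series" means these compounds.

Compound 1 `CCNC(=O)CCc1cccc2c1B(O)OC2`: in a functional assay on HCT-116 cells (Homo sapiens) for antiproliferative activity, read by MTT assay, with a stated time of 72 h (a higher number here means a weaker inhibitor, a lower number a stronger inhibitor), compound 1 gives > 100000 nM, a limit of the assay.
Compound 2 `CC(C)(C)NC(=O)CCc1cccc2c1B(O)OC2`: in this assay compound 2 gives > 100000 nM, also a limit.
Compound 3 `O=C(CCc1cccc2c1B(O)OC2)Nc1ccc(Cl)cc1`: in this assay compound 3 gives 12000 nM.

Among the compounds with values here, compound 3 holds the only number; the other two sit at the limit of > 100000 nM in this assay, at which 2 of the 3 values shown sit. The steps of an at least 8.3-fold lower number from compound 1 to compound 3 (0.92 log units; beyond the scatter) and an at least 8.3-fold lower number from compound 2 to compound 3 (0.92 log units; beyond the scatter) both favour the 4-chlorophenyl amide, while a step that the two limits leave unreadable from compound 1 to compound 2 cannot be read. Compound 4 `O=C(CCc1cccc2c1B(O)OC2)Nc1ccc(-c2ccccc2)cc1` differs from compound 3 by phenyl in place of chloro on an aromatic carbon. Within the data shown here, no measured step touches this aromatic carbon; the readable steps concern only the amide nitrogen, and both point toward the larger aryl group. A modest further lowering is expected, a 2.0-fold lower number from compound 3 to compound 4 (0.30 log units; within the scatter). Compound 4 is therefore estimated at 6000 nM, between 1500 nM and 25000 nM.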

Compound 4, half-maximal inhibitory concentration: 13000 nM
Compound 4: the middle estimate sits 2.2-fold (0.34 log units) below what was measured; the range from low to high includes it.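

In this assay, within the data shown here, the step of a 1.1-fold higher number from compound 3 to compound 4 (0.03 log units; within the scatter) is the first reading at this aromatic carbon para to a large group, with phenyl in place of chloro. The entering phenyl brings 6 heavy atoms and a six-membered aromatic ring, yet this one pair shows no change beyond the scatter. Nothing shown here explains why the two groups read alike.

On these data alone, an amine or a carboxylic acid on this aromatic carbon remains open. So does a longer chain joining the amide to the shared core.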